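Aryl swap on the shared core: from compound 1 to compound 3

The source may hold more compounds than are shown below. What is called first, only, known or untested is meant among the compounds shown, and "the series" means these compounds.

Within the data shown here, compound 1 `O=C1C=CC2(C=C1)OCC(=O)N2c1nc(-c2ccc3c(c2)OCCO3)nn1-c1ccccc1` holds the lowest of the two numbers so far: in a functional assay on HeLa cells (Homo sapiens) for antiproliferative activity, with a stated time of 5 days (on this read-out lower numbers stand for stronger inhibition and higher numbers for weaker inhibition), compound 1 gives 70 nM. The nearest is compound 2 `Cc1ccc(-n2nc(-c3ccc4ccccc4c3)nc2N2C(=O)COC23C=CC(=O)C=C3)cc1`, which in this assay gives 150 nM, a number beyond the scatter from compound 1; compound 2 differs from compound 1 in more than one place, so the pair carries no single-change lesson. Compound 3 `O=C1C=CC2(C=C1)OCC(=O)N2c1nc(-c2cccc(Cl)c2)nn1-c1ccccc1` is not yet measured. It differs from compound 1 in one place: 3-chlorophenyl in place of 2,3-dihydro-1,4-benzodioxin-6-yl on an aromatic carbon. The entering group is smaller and carries no hydrogen-bond acceptors. Among the measured compounds shown here, no step of this kind between measured compounds is known, so the direction rests only on expectation. Compound 3 is expected to give a modestly higher number, a step of a 1.9-fold higher number from compound 1 to compound 3 (0.27 log units; within the scatter) of about the size seen between the two measured compounds, because compound 1 gives 70 nM and a carbon-only aromatic group at this place has not yet matched it. In this assay compound 3 is estimated at 130 nM, within 45 nM to 400 nM.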

Compound 3, half-maximal inhibitory concentration: 45.3 nM
The estimate for compound 3 lay 2.9-fold (0.46 log units) above the measured number; the measured number falls inside the stated range.
By their numbers in this assay, from the lowest: compounds 3 and 1 (each within the scatter of the next); then compound 2.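

In this assay, among these compounds, the first pair that differs in one place reads a 1.5-fold lower number from compound 1 to compound 3 (0.19 log units; within the scatter), so the two numbers cannot be told apart. At this aromatic carbon of the five-membered ring with 3 nitrogen, 3-chlorophenyl therefore stands in for 2,3-dihydro-1,4-benzodioxin-6-yl without a step beyond the scatter, even though the entering group has no hydrogen-bond acceptors and no non-aromatic ring; in this pair, neither feature of the leaving group is required to keep the number at this level. Nothing at hand explains this result.

Still open, from the compounds shown here alone, is whether a non-aromatic group at this place, such as an amine, a carboxylic acid or a longer chain, would hold the number. Also open, going by these compounds, is whether this swap would read the same with a group other than phenyl on the ring nitrogen.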